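Benzylamide in place of dimethylamide on a shared core

The source may hold more compounds than are shown below. What is called first, only, known or untested is meant among the compounds shown, and "the series" means these compounds.

Compounds measured so far:
compound 1, `COc1ccc([N+](=O)[O-])cc1CSc1nc2cc(NC(=O)C3CCC3)ccc2n1C(C)C`, an assay on isolated protein for inhibition of Gonadotropin-releasing hormone receptor (Homo sapiens) (a lower number here means a stronger inhibitor, a higher number a weaker inhibitor), 1500 nM
compound 2, `CCCn1c(SCc2cc([N+](=O)[O-])ccc2OC)nc2cc(NC(=O)NC(C)(C)C)cc(C(=O)OC)c21`, this assay 37 nM
compound 3, `CCCn1c(SCc2cc([N+](=O)[O-])ccc2OC)nc2cc(NC(=O)NC(C)(C)C)cc(C(=O)N(C)C)c21`, this assay 270 nM

Among these three numbers compound 3 stands in the middle: compound 2 gives the lowest number and compound 1 the highest, and both steps from compound 3 to these neighbours lie beyond the scatter. Compound 2 and compound 3 share the same core and differ only at the carbonyl carbon, where a 7.3-fold higher number from compound 2 to compound 3 (0.86 log units; beyond the scatter) was seen.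

Compound 4, `CCCn1c(SCc2cc([N+](=O)[O-])ccc2OC)nc2cc(NC(=O)NC(C)(C)C)cc(C(=O)NCc3ccccc3)c21`, is built from compound 3 by a single change: benzylamino in place of dimethylamino on a carbonyl carbon. In words, the carbonyl keeps its place, but its substituent grows from a small, hydrogen-free group to a larger one carrying a benzyl group and one hydrogen-bond donor.

Among the measured compounds shown here, only one measured step touches this carbonyl position, the one from compound 2 to compound 3, and it shows that this position is sensitive, with a change of modest size. For the measured compounds named here, no measured pair shows what a benzylamino group does here, so the direction of the step is uncertain. The expectation is that compound 4 lands somewhere between compound 2 and compound 3, meaning a 2.3-fold lower number from compound 3 to compound 4 (0.35 log units; beyond the scatter), and the estimate for compound 4 in this assay is 120 nM, with a range from 30 nM to 500 nM.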

Compound 4, half-maximal inhibitory concentration: 120 nM
For compound 4 middle estimate and measured number coincide at the digits printed; the measured number falls inside the stated range.
By their numbers in this assay, from the lowest: compound 2; then compound 4; then compound 3; then compound 1.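

In this assay this carbonyl position accepts a much larger substituent without a loss: the swap from dimethylamino to benzylamino, which adds a six-membered aromatic ring and a hydrogen-bond donor, gives a 2.3-fold lower number from compound 3 to compound 4 (0.35 log units; beyond the scatter) and so recovers part of what the first amide cost. Even so, the methoxy compound keeps the lowest number of this series, with a 3.2-fold higher number from compound 2 to compound 4 (0.51 log units; beyond the scatter) and therefore both amides shown here remain weaker inhibitors than compound 2. The position therefore responds to the identity of the group on the carbonyl carbon in both directions, and a bigger group is not automatically a worse one in this pair. No measurement shown here explains why benzylamino gives a lower number than dimethylamino.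

Going by these compounds, what remains open is which part of the benzylamino group matters, the aromatic ring or the amide hydrogen, a question that methylamino, with the hydrogen and no ring, or phenethylamino, with a longer chain to the ring, could help to answer. On these data alone, it is also open how a free carboxylic acid on this carbonyl carbon would compare with compound 2 and compound 4.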